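The source may report more compounds than this note shows. Statements on the series, on what has been measured and on what is new or still open speak of the compounds shown alone.

Within the data shown here, compound 2 `CCOC(=O)c1c(-c2c(Cl)c3ccccc3oc2=O)nn(-c2cccc(Cl)c2)c1C(=O)OCC` gives 38000 nM in a functional assay on A549 cells (Homo sapiens) for cytotoxicity, read by MTT assay, with a stated time of 48 h (a higher number here means a weaker inhibitor, a lower number a stronger inhibitor), the higher of the two numbers measured so far. Compound 1 `CCOC(=O)c1c(-c2c(Cl)c3ccccc3oc2=O)nn(-c2ccc(OC)cc2)c1C(=O)OCC` gives 18000 nM in this assay, and a 2.1-fold higher number from compound 1 to compound 2 (0.32 log units; beyond the scatter). Compound 3 `CCOC(=O)c1c(-c2c(Cl)c3cc(C)ccc3oc2=O)nn(-c2cccc(Cl)c2)c1C(=O)OCC` differs from compound 2 by methyl in place of hydrogen on an aromatic carbon. Among the measured compounds shown here, the single measured step concerns the aryl group on the aromatic nitrogen and does not touch the fused ring, so no measured step bears on this change. The step to compound 3 is therefore expected to be a 1.1-fold lower number from compound 2 to compound 3 (0.04 log units; within the scatter), not beyond the scatter. Compound 3 is estimated at 35000 nM, within 15000 nM to 80000 nM.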

Compound 3, half-maximal inhibitory concentration: 128000 nM
Compound 3: the middle estimate sits 3.7-fold (0.56 log units) below what was measured; the measured number lies above the stated range.
By their numbers in this assay, from the lowest: compound 1; then compound 2; then compound 3.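

Methyl in place of hydrogen on this aromatic carbon gives a 3.4-fold higher number from compound 2 to compound 3 (0.53 log units; beyond the scatter) in this assay and shows that the fused ring system also responds to substitution, which the earlier change on the aromatic nitrogen could not show. This single pair shows the direction for methyl at this position only, towards a weaker inhibitor. Nothing measured here explains the step.

On these data alone, whether methoxy, chlorine or a longer chain such as ethyl at this carbon gives a similar step remains open. Also open, as far as these compounds go, is whether methyl has the same effect with the 4-methoxyphenyl group of compound 1 on the aromatic nitrogen.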